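Methoxy on an aromatic carbon in a cytotoxicity series

A few compounds are considered here, and "the series" means these few. Any claim that something is new, unique, unknown or untested is made for them only; others in the source may bear on it.

Compound 1 `Cc1nc(Nc2ccc(Cl)cc2)sc1C(=O)/C=C/c1ccccc1` is the reference. In a functional assay on PC-3 cells (Homo sapiens) for cytotoxicity, read by MTT assay (a lower number here means a stronger inhibitor, a higher number a weaker inhibitor), compound 1 gives 24600 nM. Compound 2 `COc1cccc(/C=C/C(=O)c2sc(Nc3ccc(Cl)cc3)nc2C)c1` carries the change (methoxy in place of hydrogen on an aromatic carbon). In this assay compound 2 reaches only the assay limit, > 25000 nM. The step is an at least 1.0-fold higher number from compound 1 to compound 2 (0.00 log units; that floor lies within the scatter). Compound 3 `Cc1ccccc1Nc1nc(C)c(C(=O)/C=C/c2ccccc2)s1` differs from compound 1 in the core substituent, (2-methylphenyl in place of 4-chlorophenyl on a nitrogen on an aromatic ring). In this assay compound 3 likewise returns a limit, > 25000 nM. The step is an at least 1.0-fold higher number from compound 1 to compound 3 (0.00 log units; that floor lies within the scatter). Both limits sit at the limit of > 25000 nM in this assay, at which 2 of the 3 values shown sit.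

Compound 4 `COc1cccc(/C=C/C(=O)c2sc(Nc3ccccc3C)nc2C)c1` is not yet measured; it differs from compound 3 by methoxy in place of hydrogen on an aromatic carbon, the same change as from compound 1 to compound 2, made at a place described in the same words. Because compound 3 already stands at > 25000 nM, the expected step is a step that the limit leaves unreadable from compound 3 to compound 4. Compound 4 is estimated at 40000 nM, within 25000 nM to 90000 nM, most likely reported as a limit.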

Compound 4, half-maximal inhibitory concentration: > 25000 nM
Compound 4: a limit, no number; the forecaster's own chance of this, stated with the estimate: 85%; the middle value is on the limit's open side.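

In this assay compound 4 gives > 25000 nM, a limit and not a number. Its steps from compound 2 and from compound 3 cannot be read. The compounds shown leave open whether methoxy changes cytotoxicity in compounds carrying the 2-methylphenyl group.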